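Swapping an ethyl for a benzyl on an aryl ether

The source may hold more compounds than are shown below. What is called first, only, known or untested is meant among the compounds shown, and "the series" means these compounds.

Measured so far in an assay on brain for inhibition of Amine oxidase [flavin-containing] B (Rattus norvegicus); on this read-out lower numbers stand for stronger inhibition and higher numbers for weaker inhibition:
Compound 1 `O=C1CSC(c2ccccc2)CN1` gives 9580 nM.
Compound 2 `CCCOc1ccc(C2CNC(=O)CS2)cc1` gives 1490 nM.
Compound 3 `CCOc1ccc(C2CNCCS2)cc1` gives 2170 nM.

Compound 3 sits second highest of the three numbers; its value is close to that of compound 2 and beyond the scatter below that of compound 1. The unmeasured compound 4 `c1ccc(COc2ccc(C3CNCCS3)cc2)cc1` differs from compound 3 by phenyl in place of methyl on a saturated chain carbon bound to an oxygen on an aromatic ring. Going by the values given here, no measured step changes that same place. Among the compounds with values here, the one step that comes nearest, a 6.4-fold lower number from compound 1 to compound 2 (0.81 log units; beyond the scatter), shows that adding an alkoxy group to the aryl ring lowered the number, but it says nothing about enlarging the group on the ether carbon. A small to modest further drop is therefore expected, a 2.7-fold lower number from compound 3 to compound 4 (0.43 log units; beyond the scatter), with wide uncertainty. Compound 4 is estimated at 800 nM in this assay, in the range 250 nM to 2500 nM.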

Compound 4, inhibition constant: 130 nM
Estimate against measurement, compound 4: 6.2-fold (0.79 log units) above, and the stated range ends above it.
By their numbers in this assay, from the lowest: compound 4; then compounds 2 and 3 (each within the scatter of the next); then compound 1.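

In this assay, phenyl in place of methyl on a saturated chain carbon bound to an oxygen on an aromatic ring brings a large change (a 17-fold lower number from compound 3 to compound 4 (1.22 log units; beyond the scatter)). Going by these compounds alone, the earlier compounds showed only that adding an alkoxy group to the aromatic ring could lower the number, not that the group on the ether carbon could matter this much. No measurement at hand explains the size of this step.

Still open, on these data alone, is whether an aromatic ring is needed here, or whether a cyclohexyl or a longer chain in the same place would serve as well.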